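A Chloro-to-Fluoro Swap on a Pyrazoline Aryl Group

The compounds below may be only part of what the source reports. "The series", "measured", "known", "first", "only" and "open" are said of these compounds alone.

Of the compounds shown here, three share one core and have been tested in a functional assay on A549 cells (Homo sapiens) for antiproliferative activity, with a stated time of 72 h; a lower number here means a stronger inhibitor, a higher number a weaker inhibitor. Compound 1 `Cn1c(N2N=C(c3ccccc3)CC2c2ccc(Cl)cc2)nc(-c2ccccc2)c(C#N)c1=O` gives 3250 nM. Compound 2 `Cn1c(N2N=C(c3ccc(Cl)cc3)CC2c2ccccc2)nc(-c2ccccc2)c(C#N)c1=O` gives 26900 nM. Compound 3 `Cn1c(N2N=C(c3ccccc3)CC2c2ccc(Cl)cc2)nc(-c2ccc(Cl)cc2)c(C#N)c1=O` gives 24700 nM, the second highest number of the three, close to compound 2 and well apart from compound 1. Going by the values given here, the one measured step, a 7.6-fold higher number from compound 1 to compound 3 (0.88 log units; beyond the scatter), changes the phenyl on the core to a 4-chlorophenyl and weakens inhibition modestly.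

Compound 4 `Cn1c(N2N=C(c3ccccc3)CC2c2ccc(F)cc2)nc(-c2ccc(Cl)cc2)c(C#N)c1=O` differs from compound 3 by fluoro in place of chloro on an aromatic carbon. No measured pair exchanges chloro for fluoro, so no step bears directly on this change; the only halogen step shown concerns a different ring and a different exchange, and compounds 1 and 2 merely show that moving a chloro between the two pyrazoline aryl groups changes the number considerably. Among the compounds with values here, since the only related step, a 7.6-fold higher number from compound 1 to compound 3 (0.88 log units; beyond the scatter), does not address fluoro at all, no movement beyond the scatter is expected. Compound 4 is therefore estimated at 22000 nM, between 8000 nM and 60000 nM, an expected step of a 1.1-fold lower number from compound 3 to compound 4 (0.05 log units; within the scatter).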

Compound 4, half-maximal inhibitory concentration: 27800 nM
Compound 4: the middle estimate sits 1.3-fold (0.10 log units) below what was measured, and the stated range covers the measured number.
By their numbers in this assay, from the lowest: compound 1; then compounds 3, 2 and 4 (each within the scatter of the next).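

In this assay, the exchange of 4-chlorophenyl for 4-fluorophenyl gives a 1.1-fold higher number from compound 3 to compound 4 (0.05 log units; within the scatter) and so does not separate the two compounds. Going by these compounds alone, this is the first direct reading of fluoro at this position: none of the earlier compounds carried it, and with the 4-chlorophenyl on the shared core held constant, chloro and fluoro are indistinguishable in this assay. No measured evidence is available to explain this result.

As far as these compounds go, it remains open whether the exchange would read the same in a compound with a plain phenyl on the core, as in compound 1. The compounds shown also leave open how a non-halogen group at this position, such as a methoxy group or an amine, would compare with chloro and fluoro.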